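The source may hold more compounds than are shown below. What is called first, only, known or untested is meant among the compounds shown, and "the series" means these compounds.

Measured so far in a functional assay on MCF7 cells (Homo sapiens) for cytotoxicity, read by MTT assay, with a stated time of 72 h; on this read-out lower numbers stand for stronger inhibition and higher numbers for weaker inhibition:
Compound 1 `COc1cccc(/C=C2\CCC/C(=C\c3cccc(Cl)c3)C2=O)c1OC`: 12000 nM
Compound 2 `COc1cccc(/C=C2\CCC/C(=C\c3cc(OC)c(OC)c(OC)c3)C2=O)c1OC`: 1400 nM
Compound 3 `COc1ccc(/C=C2\CCC/C(=C\c3cccc(Cl)c3)C2=O)cc1OC`: 6000 nM

Compound 3 gives 6000 nM and lies within the scatter of compound 1 at 12000 nM while compound 2 at 1400 nM stands clearly lower than both. Compound 4 `COc1ccc(/C=C2\CCC/C(=C\c3ccc(OC)c(OC)c3)C2=O)cc1` has not yet been measured. For the measured compounds named here, it carries 4-methoxyphenyl in place of 3-chlorophenyl on a double-bonded chain carbon bound to a double-bonded ring carbon and no measured pair isolates this change. Compound 2, which also lacks 3-chlorophenyl, reads 1400 nM in this assay and so points toward a lower number. The expected step is a modest one, estimated as a 2.0-fold lower number from compound 3 to compound 4 (0.30 log units; within the scatter) in this assay and close to the usual scatter. Compound 4 is expected at 3000 nM within an estimated range of 1000 nM to 9000 nM when it is measured.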

Compound 4, half-maximal inhibitory concentration: 7800 nM
The estimate for compound 4 lay 2.6-fold (0.41 log units) below the measured number; measured number inside the range.
By their numbers in this assay, from the lowest: compound 2; then compounds 3, 4 and 1 (each within the scatter of the next).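

In this assay, putting 4-methoxyphenyl in place of 3-chlorophenyl on a double-bonded chain carbon bound to a double-bonded ring carbon gives a 1.3-fold higher number from compound 3 to compound 4 (0.11 log units; within the scatter). For the compounds shown here, this is the first single change read at this position, and it shows that exchanging these two groups does not move the number beyond what repeat measurements would. Nothing at hand explains why the two groups read alike. The compounds shown leave open whether an amine or a carboxylic acid on this ring would shift the number beyond the scatter.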